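Working notes: one methoxy removed from compound 2

The source may report more compounds than this note shows. Statements on the series, on what has been measured and on what is new or still open speak of the compounds shown alone.

Measured so far:
compound 1, `COc1cc(-c2cc(/C=C/C(=O)c3ccc(Cl)c(Cl)c3)[nH]n2)cc(OC)c1OC`, 92%
compound 2, `COc1ccc(C(=O)/C=C/c2cc(-c3cc(OC)c(OC)c(OC)c3)n[nH]2)cc1OC`, 92%

In a functional assay on LOX IMVI cells (Homo sapiens) for cytotoxicity, read by sulforhodamine B assay, with a stated time of 48 h, tested at 0.1 uM (a higher number here means a weaker effect of the compound at the concentration tested, a lower number a stronger effect), compound 1 gives 92% and compound 2 gives 92%. Among the compounds with values here, the only measured step, no change at the digits printed from compound 1 to compound 2 (within the scatter), goes with 3,4-dimethoxyphenyl in place of 3,4-dichlorophenyl on a carbonyl carbon. Compound 2 therefore stands level with compound 1 at the digits shown, within the scatter, and both values sit near the top of the scale.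

Compound 3, `COc1ccc(C(=O)/C=C/c2cc(-c3cc(OC)c(OC)c(OC)c3)n[nH]2)cc1`, differs from compound 2 as follows: hydrogen in place of methoxy on an aromatic carbon. Within the data shown here, no measured step removes a methoxy. Among the measured compounds shown here, the one step that bears on the question is the exchange of the whole aryl group on the carbonyl carbon, which left the read-out unchanged; the smaller change from compound 2 to compound 3 touches the same ring. With both measured values this high, any movement would have to be downward, and nothing measured points to one.

For compound 3 the expected step is no change at the digits printed from compound 2 to compound 3 (within the scatter), nothing beyond the scatter. Compound 3 is estimated at 92%, with a range from 80% to 102%.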

Compound 3, a percentage reported as activity, at one concentration (the size of the read-out at that concentration, not a potency): 93%
For compound 3 the middle estimate is 1 percentage points below the measured one, and the stated range covers the measured number.
By their numbers in this assay, from the lowest: compounds 1, 2 and 3 (each within the scatter of the next).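

In this assay this position now has its first direct reading: hydrogen in place of methoxy on an aromatic carbon, ortho to a methoxy group, gives a number 1 percentage points higher from compound 2 to compound 3 (within the scatter) and does not separate the two compounds. The aryl group on the carbonyl carbon now appears in three forms, and 4-methoxyphenyl in place of 3,4-dichlorophenyl gives a number 1 percentage points higher from compound 1 to compound 3 (within the scatter) as well, so neither this one methoxy nor the exchange of the whole aryl group moves the read-out beyond the scatter. All of this is a single-concentration reading with the compounds showing little effect, so it indicates a lack of separation at this concentration and does not establish equal potency. No available evidence bears on why the read-out stays level across these changes.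

The compounds shown leave open whether this position tolerates a group of a different kind, such as an amine or a carboxylic acid in place of the methoxy. They also leave open whether the aryl group on the carbonyl carbon matters at all under conditions where the compounds give a stronger effect.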